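This account rests on a few compounds, and the source may have more. Where it says the series, first, only, none or still open, it means among the compounds named here.

Measured in a functional assay on CHO cells with adenosine receptor A1 (Homo sapiens) as the target, read by cAMP accumulation and immunoassay, with a stated time of 6 min, tested at 1 uM; a higher number here means a weaker effect of the compound at the concentration tested, a lower number a stronger effect:
Compound 1 `Nc1scc(CN2CCN(c3cccc(C(F)(F)F)c3)CC2)c1C(=O)c1ccc(Cl)cc1` gives -72%.
Compound 2 `Nc1scc(CN2CCN(c3cccc(F)c3)CC2)c1C(=O)c1ccc(Cl)cc1` gives -86%.

Compound 2 thus holds the lower of the two numbers, the stronger effect. Among the measured compounds shown here, the only known step, a number 14 percentage points lower from compound 1 to compound 2 (beyond the scatter), came with fluoro in place of trifluoromethyl on an aromatic carbon. Compound 3 `Nc1scc(CN2CCN(c3cc(F)cc(F)c3)CC2)c1C(=O)c1ccc(Cl)cc1` differs from compound 2 by fluoro in place of hydrogen on an aromatic carbon. For the measured compounds named here, no measured step adds a second fluoro to that ring, so the one known step gives only loose guidance, and a change within the scatter is expected, a number 2 percentage points higher from compound 2 to compound 3 (within the scatter). Compound 3 is therefore estimated at -84%, within -96% to -68%.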

Compound 3, a percentage reported as activity, at one concentration (the size of the read-out at that concentration, not a potency): -66%
Compound 3: the middle estimate sits 18 percentage points below what was measured; measured number outside the range, above it.
By their numbers in this assay, from the lowest: compound 2; then compounds 1 and 3 (each within the scatter of the next).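

In this assay, placing a second fluoro on the aromatic ring, which turns 3-fluorophenyl into 3,5-difluorophenyl, gave a number 20 percentage points higher from compound 2 to compound 3 (beyond the scatter), so even this single small replacement of hydrogen weakens the effect. With a number 6 percentage points higher from compound 1 to compound 3 (within the scatter), the 3,5-difluorophenyl and 3-(trifluoromethyl)phenyl groups cannot be told apart here. No measurement at hand explains the loss. Still open, on these data alone, is how a chloro or methoxy group at this same place would compare, and whether either would keep the stronger effect of compound 2.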